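The source may hold more compounds than are shown below. What is called first, only, known or untested is meant among the compounds shown, and "the series" means these compounds.

Within the data shown here, the three compounds measured so far share one core and the same methylsulfonyl-bearing aniline; they differ in the group attached to the other side of that core. Compound 1 `COc1cc2nc(OC3CCN(C(=O)OC(C)(C)C)CC3)nc(Nc3ccc(S(C)(=O)=O)cc3)c2cc1OC` and compound 2 `COc1cc2nc(OCC3CCN(C(=O)OC(C)(C)C)CC3)nc(Nc3ccc(S(C)(=O)=O)cc3F)c2cc1OC` each end in a tert-butoxycarbonyl group. In a functional assay on HEK293 cells for agonist activity at Glucose-dependent insulinotropic receptor (Homo sapiens), read by cAMP accumulation, with a stated time of 60 min (a higher number here means that more compound is needed for the effect, a lower number that less compound is needed), compound 1 gives > 10000 nM, which is a limit of the assay rather than a measured number. Compound 2 likewise gives > 10000 nM in this assay, again only a limit. Compound 3 `COc1cc2nc(Nc3ccc(S(C)(=O)=O)cc3)nc(N3CCC4CCC(C3)N4Cc3ccccc3)c2cc1OC` carries a benzyl group on its ring nitrogen instead, and in this assay compound 3 gives > 10000 nM, also a limit. So compound 3 cannot be placed above or below the others: all three values sit at the same limit, and no step between measured compounds can be read off.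

Compound 4 `COc1cc2nc(Nc3ccc(S(C)(=O)=O)cc3)nc(N3CCC4CCC(C3)N4C(=O)OC(C)(C)C)c2cc1OC` differs from compound 3 by tert-butoxycarbonyl in place of benzyl on an amine nitrogen in a ring, in words tert-butoxycarbonyl in place of benzyl on an amine nitrogen in a ring. Because compound 1 and compound 2 already carry a tert-butoxycarbonyl and sit at the limit of > 10000 nM in this assay, at which 3 of the 3 values shown sit, no rise above the scatter is expected here. The expected step is a step that the limit leaves unreadable from compound 3 to compound 4. Compound 4 is estimated at 15000 nM, with a range from 5000 nM to 50000 nM, most likely reported only as a limit.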

Compound 4, half-maximal effective concentration: > 10000 nM
Compound 4: only a limit was reported; the forecaster's own chance of this, stated with the estimate: 80%; the middle value lies beyond the limit too.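

In this assay compound 4 gives > 10000 nM, which is a limit of the assay and not a number. Compound 3 also stands at a limit, so no step between compound 3 and compound 4 can be read: the limit of > 10000 nM in this assay, at which 4 of the 4 values shown sit.

The compounds shown leave open which group on the shared core, if any, would give a measured number in this assay.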